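This account rests on a few compounds, and the source may have more. Where it says the series, first, only, none or still open, it means among the compounds named here.

Compound 3 `Cc1nn(-c2ncnc3nc[nH]c23)c2c1C(OCc1ccccc1C#N)CC(=O)N2` sits at 8 nM in a functional assay on HEK293 cells for agonist activity at G-protein coupled receptor 39 (Homo sapiens), read by scintillation proximity assay and inositol phosphate accumulation, with a stated time of 75 min, in the presence of a further agent that is not named here (a higher number here means that more compound is needed for the effect, a lower number that less compound is needed), level with compound 2 `CCCCCCCCOC1CC(=O)Nc2c1c(C)nn2-c1ncnc2nc[nH]c12`, which gives 8 nM; compound 1 `Cc1cc(C)n(CCOC2CC(=O)Nc3c2c(C)nn3-c2ncnc3nc[nH]c23)n1` gives 16 nM. The steps among these three all fall inside the scatter: a 2.0-fold lower number from compound 1 to compound 2 (0.30 log units; within the scatter), a 2.0-fold lower number from compound 1 to compound 3 (0.30 log units; within the scatter), no change at the digits printed from compound 2 to compound 3 (within the scatter). The ether-linked side chain has thus accepted a hexyl, a (3,5-dimethyl-1H-pyrazol-1-yl)methyl and a 2-cyanophenyl terminus without a change beyond the scatter.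

Compound 4 `Cc1nn(-c2ncnc3nc[nH]c23)c2c1C(C(=O)NCc1ccccc1)CC(=O)N2` departs from compound 3 by benzylcarbamoyl in place of (2-cyanobenzyl)oxy on a saturated ring carbon. Within the data shown here, none of the measured steps touches the ether oxygen itself; each only swaps the group beyond it, so they speak only indirectly to this step. They show that the terminus is tolerant, but they give no measurement for an amide carbonyl and an amide hydrogen standing where the ether oxygen stood. For that reason the expectation is a step no larger than modest, more likely towards a higher number than a lower one, with a wide range to cover the lack of a direct precedent: compound 4 is estimated to give 30 nM in this assay, between 5 nM and 200 nM, which means an expected step of a 3.8-fold higher number from compound 3 to compound 4 (0.57 log units; beyond the scatter).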

Compound 4, half-maximal effective concentration: 5 nM
Compound 4: the middle estimate sits 6.0-fold (0.78 log units) above what was measured; the measured number falls inside the stated range.
By their numbers in this assay, from the lowest: compounds 4, 2, 3 and 1 (each within the scatter of the next, the first and the last beyond it).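

In this assay, the saturated ring carbon three ring bonds from the ring nitrogen accepts benzylcarbamoyl in place of (2-cyanobenzyl)oxy with a 1.6-fold lower number from compound 3 to compound 4 (0.20 log units; within the scatter) and thus carries an amide linkage as well as an ether linkage, so the ether oxygen is not needed here to stay within the scatter. The comparison with the simple chain gives the same reading, a 1.6-fold lower number from compound 2 to compound 4 (0.20 log units; within the scatter) on exchanging octyloxy for benzylcarbamoyl, which extends the earlier finding from the terminus to the link itself. Among these compounds, the one step in this set beyond the scatter is modest, a 3.2-fold lower number from compound 1 to compound 4 (0.51 log units; beyond the scatter) on replacing the pyrazole-bearing ether with benzylcarbamoyl, and since the link and the terminus change together, it cannot be assigned to either one.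

Still open, on these data alone, is how far the amide itself matters: an N-methyl amide, a reversed amide, an amine or a carboxylic acid on this ring carbon would each test a different part of the link, and a 2-cyanobenzyl amide would separate the nitrile from the link. Nothing available bears on why this position accepts these changes.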